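Replacing furan-3-yl with pyridin-3-yl in compound 1

The source may report more compounds than this note shows. Statements on the series, on what has been measured and on what is new or still open speak of the compounds shown alone.

- compound 1 `COc1cc(C(=O)c2cn(-c3cccc(C)c3)cc2-c2ccoc2)cc(OC)c1OC` gives 21 nM
- compound 2 `COc1cc(C(=O)c2cn(-c3ccc(C)cc3)cc2-c2ccoc2)cc(OC)c1OC` gives 18 nM
- compound 3 `COc1cc(C(=O)c2cn(-c3ccc(F)cc3)cc2-c2ccoc2)cc(OC)c1OC` gives 15 nM

These values come from a functional assay on MCF7 cells (Homo sapiens) for inhibition, with a stated time of 96 h (a lower number here means a stronger inhibitor, a higher number a weaker inhibitor), and are close together. Compound 1 stands within the scatter of both others, with a 1.2-fold lower number from compound 1 to compound 2 (0.07 log units; within the scatter) and a 1.4-fold lower number from compound 1 to compound 3 (0.15 log units; within the scatter) as its steps. Compound 4 `COc1cc(C(=O)c2cn(-c3cccc(C)c3)cc2-c2cccnc2)cc(OC)c1OC` has pyridin-3-yl in place of furan-3-yl on an aromatic carbon, a change counted as pyridin-3-yl in place of furan-3-yl on an aromatic carbon in full. The measured steps, including a 1.2-fold lower number from compound 2 to compound 3 (0.08 log units; within the scatter) as the third, all concern the group on an aromatic nitrogen, so none tests this swap. Starting from compound 1 at 21 nM in this assay as the reference, a modest move to a higher number is expected, with wide uncertainty. The expected change is a 1.9-fold higher number from compound 1 to compound 4 (0.28 log units; within the scatter) as an estimate. Compound 4 is estimated at 40 nM with an expected range from 12 nM to 140 nM in this assay overall.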

Compound 4, half-maximal inhibitory concentration: 52 nM
For compound 4 the middle estimate is 1.3-fold (0.11 log units) below the measured one; low and high end bracket the measured number.
By their numbers in this assay, from the lowest: compounds 3, 2 and 1 (each within the scatter of the next); then compound 4.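

Here the change falls on the aromatic carbon rather than on the aromatic nitrogen, where the earlier steps all stayed within the scatter. In this assay, pyridin-3-yl in place of furan-3-yl gives a 2.5-fold higher number from compound 1 to compound 4 (0.39 log units; beyond the scatter), so this position does respond to a change of ring, though only modestly. Nothing available here explains this shift.

From the compounds shown here alone, whether ring size or the ring hetero atom matters more remains open, and thiophen-3-yl or an amine at this position would help separate them. Going by these compounds, whether the step carries over to the 4-fluorophenyl group of compound 3 is also open.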